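The source may hold more compounds than are shown below. What is called first, only, known or untested is meant among the compounds shown, and "the series" means these compounds.

Measured compounds:
compound 1, `CC(/C=N/Nc1ccc([N+](=O)[O-])cc1)=N\NC(=O)c1ccccc1`; in a functional assay on cells (Splenocyte, Mus musculus, strain BALB/c) for inhibition, read by scintillation counting and thymidine incorporation, with a stated time of 72 h (on this read-out higher numbers stand for weaker inhibition and lower numbers for stronger inhibition), compound 1 gives > 12000 nM, which is a limit of the assay and not a number.
compound 2, `CC(/C=N/Nc1ccc([N+](=O)[O-])cc1)=N\NC(=O)c1ccc(N)cc1`; in this assay compound 2 gives > 12000 nM, also a limit.

Compound 2 therefore stands at the limit of > 12000 nM in this assay, at which 2 of the 2 values shown sit, so only a bound is known for it. Among the compounds with values here, the only measured step, a step that the two limits leave unreadable from compound 1 to compound 2, cannot be sized. Compound 3, `CC(/C=N/Nc1ccc([N+](=O)[O-])cc1)=N\NC(=O)c1ccccc1N`, differs from compound 2 by 2-aminophenyl in place of 4-aminophenyl on a carbonyl carbon. No readable step bears on this change, so no direction beyond the scatter is expected. The expected step is a step that the limit leaves unreadable from compound 2 to compound 3. Compound 3 is estimated at 15000 nM, with a range from 5000 nM to 50000 nM, most likely again only a limit.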

Compound 3, half-maximal inhibitory concentration: 4900 nM
Beside the measured number, compound 3's estimate is 3.1-fold (0.49 log units) above it, outside the stated range (below it).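

In this assay, 2-aminophenyl in place of 4-aminophenyl on the carbonyl carbon gives an at least 2.4-fold lower number from compound 2 to compound 3 (0.38 log units; beyond the scatter), so with the same atoms, how the amino group is joined to the ring changes the result. Amino in place of hydrogen also gives an at least 2.4-fold lower number from compound 1 to compound 3 (0.38 log units; beyond the scatter), while the step from compound 1 to compound 2 cannot be read. Both readable steps give only a minimum size because their starting compounds sit at a limit: the limit of > 12000 nM in this assay, at which 2 of the 3 values shown sit.

The compounds shown leave open whether the amino group itself matters in 2-aminophenyl. A hydroxyl or a carboxylic acid in its place would test this.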